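This account rests on a few compounds, and the source may have more. Where it says the series, first, only, none or still open, it means among the compounds named here.

- Compound 1 `O=C(CCCCCC(=O)NCc1ccc2cc(Cl)ccc2n1)NO` – 1840 nM
- Compound 2 `O=C(CCCCCC(=O)NCc1ccc2cc(Br)ccc2n1)NO` – 900 nM

Among the measured compounds shown here, in a functional assay on MDA-MB-231 cells (Homo sapiens) for inhibition, read by MTT assay, with a stated time of 48 h (a higher number here means a weaker inhibitor, a lower number a stronger inhibitor), compound 2 gives 900 nM, the lower of the two numbers so far, which makes it the stronger inhibitor of the pair. Compound 3 `O=C(CCCCCC(=O)NCc1ccc2cc(I)ccc2n1)NO` makes one change to compound 2: iodo in place of bromo on an aromatic carbon. For the measured compounds named here, only one measured step bears on this, a similar swap of bromo in place of chloro on the same aromatic carbon. That step was modest: a 2.0-fold lower number from compound 1 to compound 2 (0.31 log units; beyond the scatter). A similar or smaller move toward a lower number is therefore expected, and it may not clear the scatter. The estimated step is a 1.4-fold lower number from compound 2 to compound 3 (0.14 log units; within the scatter). Compound 3 is expected at 650 nM, with an estimated range of 280 nM to 1500 nM.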

Compound 3, half-maximal inhibitory concentration: 1410 nM
For compound 3 the middle estimate is 2.2-fold (0.34 log units) below the measured one, and the stated range covers the measured number.
By their numbers in this assay, from the lowest: compounds 2, 3 and 1 (each within the scatter of the next, the first and the last beyond it).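

Iodo at this position does not continue the move seen with bromo: the result is a 1.6-fold higher number from compound 2 to compound 3 (0.19 log units; within the scatter), and against the chloro compound it is a 1.3-fold lower number from compound 1 to compound 3 (0.12 log units; within the scatter). Compound 3 therefore lies within the scatter of both other compounds, so the three halogens on this aromatic carbon show no steady trend. No measurement is available to explain this result.

Still open, going by these compounds, is whether a non-halogen group at this position, such as a methoxy group or an amine, would shift the number beyond the scatter. Also open, on these data alone, is what a longer chain would do.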